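This account rests on a few compounds, and the source may have more. Where it says the series, first, only, none or still open, it means among the compounds named here.

Three analogues of one series have been tested in a functional assay on MIA PaCa-2 cells (Homo sapiens) for antiproliferative activity; a lower number here means that less compound is needed, a higher number that more compound is needed for the effect. Compound 1 `CCC#CC(=O)Nc1cccc2c1cc(C)n2-c1nc2c(c(NCc3ccccc3)n1)CCCC2` gives 463 nM, and compound 2 `CCCC#CC(=O)Nc1cccc2c1cc(C)n2-c1nc2c(c(NCc3ccccc3)n1)CCCC2` gives 1570 nM; the change methyl in place of hydrogen on a saturated chain carbon, two bonds along the chain from a triple-bonded carbon produced a 3.4-fold higher number from compound 1 to compound 2 (0.53 log units; beyond the scatter). Compound 3 `C#CC(=O)Nc1cccc2c1cc(C)n2-c1nc2c(c(NCc3ccccc3)n1)COCC2` gives 78.7 nM; how its core differs from that of compound 1 is not broken down here. Compound 4 `CC#CC(=O)Nc1cccc2c1cc(C)n2-c1nc2c(c(NCc3ccccc3)n1)COCC2` differs from compound 3 by methyl in place of hydrogen on a triple-bonded carbon. This is the same kind of change as from compound 1 to compound 2, but not the same: there the methyl entered on a saturated chain carbon, two bonds along the chain from a triple-bonded carbon, here it enters on a triple-bonded carbon whose other neighbour is a triple-bonded carbon. Because the earlier methyl gave a 3.4-fold higher number from compound 1 to compound 2 (0.53 log units; beyond the scatter), a step of similar direction is expected here, a 2.5-fold higher number from compound 3 to compound 4 (0.41 log units; beyond the scatter), so compound 4 is estimated at 200 nM, between 70 nM and 600 nM.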

Compound 4, half-maximal effective concentration in the MIA PaCa-2 assay: 600 nM
For compound 4 the middle estimate is 3.0-fold (0.48 log units) below the measured one, within the range that was stated.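

In the MIA PaCa-2 assay the added methyl again raises the number, a 7.6-fold higher number from compound 3 to compound 4 (0.88 log units; beyond the scatter), and this rise cannot be told apart from the earlier one on the other core: the same change on two cores in the MIA PaCa-2 assay, a 3.4-fold higher number (0.53 log units; beyond the scatter) from compound 1 to compound 2 and a 7.6-fold higher number (0.88 log units; beyond the scatter) from compound 3 to compound 4, 2.2-fold (0.35 log units) apart, within the scatter of two such steps. The step from hydrogen to methyl on the triple-bonded carbon also goes with a far longer half-life in a physicochemical assay for pharmacokinetics, read by LC-MS, in phosphate buffer, tested at 1 uM; on this read-out lower numbers stand for a shorter-lived compound and higher numbers for a longer-lived compound: the measured half-life of compound 3, 0.21 h, and of compound 4, 16.2 h, a 77-fold higher number (1.89 log units; beyond the scatter). In the physicochemical assay compound 3 gives 0.21 h and compound 4 gives 16.2 h. So the direction of the potency loss carried over between these two cores, but two steps, with the methyl entering at different places, make no general rule, and the half-life gain rests on this single pair.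

From the compounds shown here alone, it remains open whether the half-life gain also appears on the core of compound 1. Going by these compounds, it is also open whether a longer chain or an amine on the triple-bonded carbon would behave like methyl in the MIA PaCa-2 assay.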